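This account rests on a few compounds, and the source may have more. Where it says the series, first, only, none or still open, it means among the compounds named here.

Compound 1, `O=C(/C=C/c1ccccc1Oc1ccccc1)NO`, gives 66000 nM.
Compound 2, `O=C(/C=C/c1ccc(Oc2ccccc2)cc1)NO`, gives 20000 nM.
Compound 3, `O=C(/C=C/c1ccccc1OCc1ccccc1)NO`, gives 31000 nM.

All three numbers come from an ADME assay on Huh-7 cells (Homo sapiens) for cytotoxicity, read by MTT assay, with a stated time of 3 days; on this read-out higher numbers stand for lower toxicity in this test and lower numbers for higher toxicity in this test. Among them, compound 3 holds the second highest of the three numbers. Its nearest neighbour is compound 2, whose number lies within the usual scatter of it, so the two cannot be told apart on this test. Its furthest neighbour is compound 1, whose number is higher by a margin beyond the scatter, which marks compound 1 as the less toxic of that pair.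

Compound 4, `COc1ccccc1/C=C/C(=O)NO`, has not yet been measured. Its structure differs from that of compound 3 in one place: hydrogen in place of phenyl on a saturated chain carbon bound to an oxygen on an aromatic ring. For the measured compounds named here, no measured pair in this set shows a step of this kind, so the direction is not fixed by the data. The number is expected to rise a little, toward lower toxicity, and the step might just reach beyond the scatter. Compound 4 is expected to give about 60000 nM, within a range from 25000 nM to 150000 nM. That estimate amounts to an expected step of a 1.9-fold higher number from compound 3 to compound 4 (0.29 log units; within the scatter).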

Compound 4, half-maximal cytotoxic concentration: 30000 nM
Compound 4: the middle estimate sits 2.0-fold (0.30 log units) above what was measured; low and high end bracket the measured number.
By their numbers in this assay, from the lowest: compounds 2, 4 and 3 (each within the scatter of the next); then compound 1.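

Replacing phenyl with hydrogen on the saturated chain carbon bound to an oxygen on an aromatic ring produces no readable change in this assay (a 1.0-fold lower number from compound 3 to compound 4 (0.01 log units; within the scatter)), so this phenyl can be lost without a measurable shift in toxicity in this test. The picture differs when phenyl sits directly on the oxygen: methyl in its place gives a 2.2-fold lower number from compound 1 to compound 4 (0.34 log units; beyond the scatter), a modest move beyond the scatter toward higher toxicity in this test. The same small methyl-bearing compound therefore matches one phenyl-bearing neighbour but not the other, so the effect of losing phenyl depends on how that ring is attached.

From the compounds shown here alone, whether a longer chain, such as propyl, or a chain ending in an amine would behave the same way on this oxygen remains open. Nothing here explains the difference between the two steps.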